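The source may report more compounds than this note shows. Statements on the series, on what has been measured and on what is new or still open speak of the compounds shown alone.

Two compounds of this series have been examined in a physicochemical assay for solubility, at pH 7; a higher number here means a more soluble compound, a lower number a less soluble compound. Compound 1, `CN1CCC(C(=O)Nc2n[nH]c3c2CN(C(=O)C(C)(C)C)C3(C)C)CC1`, carries a methylpiperidine amide on the shared core. In this assay compound 1 reaches only the limit of the measurement, > 225000 nM. Compound 2, `CCCNC(=O)Nc1n[nH]c2c1CN(C(=O)C1CCN(C)CC1)C2(C)C`, also gives a limit rather than a number in this assay, namely > 225000 nM. Thus both values sit at the limit of > 225000 nM in this assay, at which 2 of the 2 values shown sit, and the two compounds cannot be told apart on these numbers.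

Compound 3, `CN1CCC(C(=O)N2Cc3c(NC(=O)c4cc(F)cc(F)c4)n[nH]c3C2(C)C)CC1`, is the next compound to be measured in this assay. It differs from compound 2 by 3,5-difluorophenyl in place of propylamino on a carbonyl carbon. Among the compounds with values here, no measured step of this kind exists among the compounds so far, so the size of the change is not yet fixed by any observation. A step from compound 2 to compound 3 downward, estimated at an at least 2.5-fold lower number from compound 2 to compound 3 (0.39 log units; beyond the scatter), is expected. Compound 3 is accordingly expected to give about 90000 nM, within a range of 15000 nM to 225000 nM.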

Compound 3, solubility: > 225000 nM
Compound 3: only a limit was reported; the forecaster's own chance of this, stated with the estimate: 40%; middle value at least 2.5-fold (0.39 log units) from the limit.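

In this assay compound 3 gives > 225000 nM, which is a limit and not a number. No step from compound 2 to compound 3 can therefore be read, and the three compounds stay apart on no number: the limit of > 225000 nM in this assay, at which 3 of the 3 values shown sit.

The compounds shown leave open whether 3,5-difluorophenyl in place of propylamino on a carbonyl carbon shifts the read-out in this assay at all.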